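The compounds below may be only part of what the source reports. "The series", "measured", "known", "first", "only" and "open" are said of these compounds alone.

Compound 2 `CCCCN1CCC(C(=O)Nc2cc(Cl)c(N)cc2OC)CC1` stands in a functional assay on the whole organism for antagonist activity, with Mus musculus as the target (on this read-out higher numbers stand for an effect only at larger amounts of compound and lower numbers for an effect already at smaller amounts), at a limit only, > 10 mg/kg. Compound 1 `COc1cc(N)c(Cl)cc1NC(=O)C1CCN(CC2CCCCC2)CC1` gives in this assay a number, 2.9 mg/kg. Compound 3 `COc1cc(N)c(Cl)cc1NC(=O)C1CCN(Cc2cccc(C#N)c2)CC1` also sits at a limit in this assay, > 4 mg/kg. The unmeasured compound 4 `COc1cc(N)c(Cl)cc1NC(=O)C1CCN(C2CCCC2)CC1` differs from compound 2 by cyclopentyl in place of butyl on an amine nitrogen in a ring. The step that bears on this change is an at least 3.4-fold higher number from compound 1 to compound 2 (0.53 log units; beyond the scatter), in which cyclohexyl gave way to propyl on that amine nitrogen and the number rose. The companion step an at least 1.3-fold higher number from compound 1 to compound 3 (0.13 log units; that floor lies within the scatter) is less informative. Compound 4 puts a cyclopentyl back on that nitrogen, so a move to a lower number is expected for it, an at least 2.2-fold lower number from compound 2 to compound 4 (0.34 log units; beyond the scatter). Compound 4 is therefore estimated at 4.5 mg/kg, with a range from 2 mg/kg to 12 mg/kg.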

Compound 4, dose for half-maximal effect: > 10 mg/kg
Compound 4: a limit, no number (the forecaster's own chance of this, stated with the estimate: 30%); middle value at least 2.2-fold (0.34 log units) from the limit.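

In this assay, a carbon ring set directly on this amine nitrogen does not by itself bring the lower number of compound 1: with cyclopentyl in place of cyclohexylmethyl, the result is an at least 3.4-fold higher number from compound 1 to compound 4 (0.53 log units; beyond the scatter). Of the compounds shown, only compound 1 with its cyclohexylmethyl group still gives a number. The steps from compound 2 and from compound 3 to compound 4 cannot be read, and the value of compound 4 is a limit, not a number: the limit of > 10 mg/kg in this assay, at which 2 of the 4 values shown sit.

Going by these compounds, it remains open how compound 2 and compound 4 truly compare. Also open, on these data alone, is whether cyclohexyl directly on that nitrogen, or a cyclohexylethyl chain, would give a number in this assay.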